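A few compounds are considered here, and "the series" means these few. Any claim that something is new, unique, unknown or untested is made for them only; others in the source may bear on it.

Compound 1 `O/N=C(/Nc1cccc(Cl)c1)c1ccc2occc2c1`: 1500 nM
Compound 2 `OCc1cc2cc(/C(=N\O)Nc3cccc(Cl)c3)ccc2o1`: 5900 nM
Compound 3 `OCc1cc2cc(/C(=N\O)Nc3cccc(Br)c3)ccc2o1`: 1200 nM

In an assay on tissue (HeLa cells) for inhibition of Indoleamine 2,3-dioxygenase 1 (Homo sapiens), read by spectrophotometry (a higher number here means a weaker inhibitor, a lower number a stronger inhibitor), compound 2 stands at the weak end of these three: a 3.9-fold higher number from compound 1 to compound 2 (0.59 log units; beyond the scatter) and a 4.9-fold lower number from compound 2 to compound 3 (0.69 log units; beyond the scatter) both separate it clearly from its neighbours. Compound 4 `COCc1cc2cc(/C(=N\O)Nc3cccc(Cl)c3)ccc2o1` differs from compound 2 by methyl in place of hydrogen on an oxygen on a saturated carbon, which turns the hydroxymethyl group into a methoxymethyl group. For the measured compounds named here, no measured step changes this oxygen; the nearest is the one that introduced the hydroxymethyl group, a 3.9-fold higher number from compound 1 to compound 2 (0.59 log units; beyond the scatter), and it says nothing about what capping that group does. The expectation is therefore modest: a step of a 1.2-fold lower number from compound 2 to compound 4 (0.07 log units; within the scatter), within the scatter, in this assay. Compound 4 is estimated at 5000 nM, with a range from 1500 nM to 16000 nM.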

Compound 4, half-maximal inhibitory concentration: 2200 nM
For compound 4 the middle estimate is 2.3-fold (0.36 log units) above the measured one, within the range that was stated.
By their numbers in this assay, from the lowest: compounds 3, 1 and 4 (each within the scatter of the next); then compound 2.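

Capping the hydroxy oxygen with methyl matters in this assay (a 2.7-fold lower number from compound 2 to compound 4 (0.43 log units; beyond the scatter)), so the result at this position depends on more than the presence of a substituent on that aromatic carbon. Methoxymethyl cannot be told apart from plain hydrogen there (a 1.5-fold higher number from compound 1 to compound 4 (0.17 log units; within the scatter)), so among these chloro compounds, only the free hydroxymethyl group gives a weaker inhibitor. No measurement shown explains this difference.

Still open, going by these compounds, is how an aminomethyl group or a carboxylic acid would behave at this position. Also open, on these data alone, is whether bromo in place of chloro would change the methoxymethyl compound as it changed the hydroxymethyl one.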